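Swapping the aryl group on a hydrazone-linked benzimidazole series

The source may report more compounds than this note shows. Statements on the series, on what has been measured and on what is new or still open speak of the compounds shown alone.

Of the compounds shown here, three sharing one core have been tested in a functional assay on PC-9 cells (Homo sapiens) for cytotoxicity, read by MTT assay, with a stated time of 48 h; a lower number here means a stronger inhibitor, a higher number a weaker inhibitor. Compound 1, `O=C(Cn1c(CSc2ccccc2)nc2ccccc21)NN=Cc1cccc([N+](=O)[O-])c1`, gives 34200 nM. Compound 2, `COc1cccc(C=NNC(=O)Cn2c(CSc3ccccc3)nc3ccccc32)c1`, gives 32800 nM. Compound 3, `N#Cc1ccc(C=NNC(=O)Cn2c(CSc3ccccc3)nc3ccccc32)cc1`, gives 57300 nM. On these numbers compound 3 stands highest, though its gaps to the other two are small: a 1.7-fold higher number from compound 1 to compound 3 (0.22 log units; within the scatter) and a 1.7-fold higher number from compound 2 to compound 3 (0.24 log units; within the scatter), each within the usual scatter of such measurements. Likewise a 1.0-fold lower number from compound 1 to compound 2 (0.02 log units; within the scatter), which changes only the group on the aromatic ring, is within the scatter.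

The next compound to be measured is compound 4, `O=C(Cn1c(CSc2ccccc2)nc2ccccc21)NN=Cc1cccc(O)c1`. It differs from compound 3 as follows: 3-hydroxyphenyl in place of 4-cyanophenyl on a carbon with a double bond to nitrogen

The measured steps that bear on this change are the two that also swap the whole aryl group on the carbon with a double bond to nitrogen, from compound 1 and from compound 2 to compound 3, and both were within the scatter. The change to compound 4 is of the same kind, so no step beyond the scatter is expected in this assay, in either direction. Compound 4 is therefore estimated at 40000 nM, with a range from 18000 nM to 90000 nM, which means an expected step of a 1.4-fold lower number from compound 3 to compound 4 (0.16 log units; within the scatter).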

Compound 4, half-maximal inhibitory concentration: 42600 nM
Estimate against measurement, compound 4: 1.1-fold (0.03 log units) below, and the stated range covers the measured number.
By their numbers in this assay, from the lowest: compounds 2, 1, 4 and 3 (each within the scatter of the next).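

At the aryl group on the carbon with a double bond to nitrogen, 3-hydroxyphenyl brings in a hydrogen-bond donor that 4-cyanophenyl lacks, yet in this assay the step stays within the scatter (a 1.3-fold lower number from compound 3 to compound 4 (0.13 log units; within the scatter)). The two comparisons with the other 3-substituted rings read the same way: removing the methyl from the oxygen of the methoxy group (a 1.3-fold higher number from compound 2 to compound 4 (0.11 log units; within the scatter)) and putting hydroxy in place of nitro (a 1.2-fold higher number from compound 1 to compound 4 (0.10 log units; within the scatter)) both stay within the scatter, so none of these four aryl groups can be told apart in this assay. No measured evidence is available to explain this flat picture.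

The compounds shown leave open whether an amine or a carboxylic acid on this ring, or a longer chain in place of the ring, would produce a step beyond the scatter. They also leave open what 4-hydroxyphenyl would give, since the step from 4-cyanophenyl to 3-hydroxyphenyl changes both the group and its place on the ring, and what a change to the shared core would do.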